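The source may report more compounds than this note shows. Statements on the series, on what has been measured and on what is new or still open speak of the compounds shown alone.

Compound 1 `Cc1cc(NC(=O)Nc2cccc(Cl)c2)c2ccccc2n1`: in an ADME assay on Raji cells (Homo sapiens) for cytotoxicity, with a stated time of 72 h (on this read-out lower numbers stand for an effect already at smaller amounts and higher numbers for an effect only at larger amounts of compound), compound 1 gives 18000 nM.
Compound 2 `Cc1cc(NC(=O)Nc2ccc(O)cc2)c2ccccc2n1`: in this assay compound 2 gives > 25000 nM, a limit of the assay rather than a number.
Compound 3 `Cc1cc(NC(=O)Nc2ccccc2N)c2ccccc2n1`: in this assay compound 3 gives > 25000 nM, likewise a limit and not a number.

Compound 3 therefore stands at the limit of > 25000 nM in this assay, at which 2 of the 3 values shown sit. Of the measured steps that touch it, an at least 1.3-fold higher number from compound 1 to compound 3 (0.14 log units; that floor lies within the scatter), and there is a step that the two limits leave unreadable from compound 2 to compound 3. Compound 4 `Cc1cc(NC(=O)Nc2cccnc2)c2ccccc2n1` differs from compound 3 by pyridin-3-yl in place of 2-aminophenyl on an amide-type nitrogen. With no readable step size in hand, the expectation rests on compound 3 sitting at the limit; the change is expected to bring an at least 1.1-fold lower number from compound 3 to compound 4 (0.05 log units; that floor lies within the scatter). Compound 4 is estimated at 22000 nM, with a range from 9000 nM to 25000 nM.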

Compound 4, half-maximal effective concentration: > 25000 nM
Compound 4 ended at the assay's limit (the forecaster's own chance of this, stated with the estimate: 60%); middle value at least 1.1-fold (0.05 log units) from the limit.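

In this assay, pyridin-3-yl, a ring with a hetero atom, now joins the groups on the amide-type nitrogen that reach the limit of the read-out, and this value for compound 4 is a limit, not a number: the limit of > 25000 nM in this assay, at which 3 of the 4 values shown sit.
For the compounds shown here, the only readable comparison is an at least 1.3-fold higher number from compound 1 to compound 4 (0.14 log units; that floor lies within the scatter), and the steps among compound 2, compound 3 and compound 4 cannot be read.

As far as these compounds go, it remains open whether these three groups differ at all beyond the limit. From the compounds shown here alone, how a carboxylic acid or a longer alkyl chain would behave on this nitrogen also remains open.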